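Methylpiperazine in place of piperidine on the amino-bearing core

This account rests on a few compounds, and the source may have more. Where it says the series, first, only, none or still open, it means among the compounds named here.

Compound 2 `C=CC(=O)Nc1cc(N)nc(Sc2c(OC)nc(N3CCCCC3)nc2OC)n1` gives 9000 nM in a functional assay on SK-BR-3 cells (Homo sapiens) for inhibition, read by resazurin assay, with a stated time of 72 h (on this read-out higher numbers stand for weaker inhibition and lower numbers for stronger inhibition), the higher of the two numbers recorded so far. For the measured compounds named here, compound 1 `C=CC(=O)Nc1ccnc(Sc2c(C)nc(N3CCN(C)CC3)nc2C)n1` gives 1800 nM in this assay; the gap between the two lies beyond the scatter, but the structures differ in several places, so no single step can be drawn from them. Compound 3 `C=CC(=O)Nc1cc(N)nc(Sc2c(OC)nc(N3CCN(C)CC3)nc2OC)n1` differs from compound 2 by 4-methylpiperazin-1-yl in place of piperidin-1-yl on an aromatic carbon. Going by the values given here, no measured pair isolates this exchange. A modest expected step of a 1.8-fold lower number from compound 2 to compound 3 (0.26 log units; within the scatter) toward a lower number is assumed, without direct support. Compound 3 is estimated at 5000 nM, within 1500 nM to 16000 nM.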

Compound 3, half-maximal inhibitory concentration: 800 nM
Beside the measured number, compound 3's estimate is 6.3-fold (0.80 log units) above it, and the stated range ends above it.
By their numbers in this assay, from the lowest: compound 3; then compound 1; then compound 2.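

For the compounds shown here, with the rest of compound 2 unchanged, 4-methylpiperazin-1-yl in place of piperidin-1-yl gives the first single-place step in this assay (an 11-fold lower number from compound 2 to compound 3 (1.05 log units; beyond the scatter)), a large one. The aromatic carbon between two ring nitrogen atoms is therefore not indifferent to the six-membered ring attached there, which the earlier pair, differing in several places, could not show. Nothing available accounts for this step.

Open, going by these compounds, is whether the step tracks the second ring nitrogen or its methyl group, a question that piperazin-1-yl or morpholin-4-yl at this carbon would address. Also open, on these data alone, is whether the same exchange gives a comparable step on the core of compound 1.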